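This account rests on a few compounds, and the source may have more. Where it says the series, first, only, none or still open, it means among the compounds named here.

Measured so far:

- compound 1, `COc1cc2c(cc1OC)C(CC(=O)O)CC2`, gives 24% in a functional assay on the whole organism (strain Wistar) for inhibition, with Rattus norvegicus as the target, read by paw edema, with stated times of 60 min and 2 h, at a dose of 100 mg/kg by the oral route; a lower number here means less inhibition, a higher number more inhibition at the dose given (going by the name of the read-out)
- compound 2, `COc1cc2c(cc1OC)C(CC(=O)N(C)C)CC2`, gives 36%
- compound 3, `COc1cc2c(cc1OC)C(CC(=O)N1CCCC1)CC2`, gives 20%

All three share one core and differ only in the group on the carbonyl carbon. Compound 3 has the lowest of the three numbers: it sits close to compound 1, within the usual scatter, and clearly below compound 2, as the step of a number 16 percentage points lower from compound 2 to compound 3 (beyond the scatter) shows. Compound 4, `COc1cc2c(cc1OC)C(CC(=O)N1CCNCC1)CC2`, is the next change in the same place: piperazin-1-yl in place of pyrrolidin-1-yl on a carbonyl carbon.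

Among the compounds with values here, two measured steps touch this position. The step of a number 12 percentage points higher from compound 1 to compound 2 (beyond the scatter) raised the number modestly, while the step of a number 16 percentage points lower from compound 2 to compound 3 (beyond the scatter) took it back down. The step of a number 4 percentage points lower from compound 1 to compound 3 (within the scatter) stayed within the scatter. Nothing measured separates a piperazin-1-yl from a pyrrolidin-1-yl, so no direction is well founded. For compound 4 a step of a number 4 percentage points higher from compound 3 to compound 4 (within the scatter) is expected, within the scatter. Compound 4 is estimated at 24%, within a range from 8% to 40%.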

Compound 4, a percentage reported as inhibition, in the whole organism at one dose (the size of the read-out at that dose, not a potency): 44%
Compound 4: middle estimate off by 20 percentage points, on the low side; the whole stated range lies below it.
By their numbers in this assay, from the lowest: compounds 3 and 1 (each within the scatter of the next); then compounds 2 and 4 (each within the scatter of the next).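

On a carbonyl carbon, the ring is not a neutral choice: in this assay the step of a number 24 percentage points higher from compound 3 to compound 4 (beyond the scatter) shows that piperazin-1-yl and pyrrolidin-1-yl, both attached through a ring nitrogen, can give clearly different results. The step of a number 20 percentage points higher from compound 1 to compound 4 (beyond the scatter) also puts piperazin-1-yl clear of the hydroxy group, whereas the step of a number 8 percentage points higher from compound 2 to compound 4 (within the scatter) does not separate piperazin-1-yl from dimethylamino. No measurement of any property of these groups bears on this result, so the difference remains unexplained.

The compounds shown leave open whether the higher number goes with the second ring nitrogen or with the six-membered ring itself. A piperidine ring, with a carbon in place of that nitrogen, and a morpholine ring, with an oxygen there, would help separate the two.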